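Ester variation on the shared core: a chlorophenyl ethenyl ester

The compounds below may be only part of what the source reports. "The series", "measured", "known", "first", "only" and "open" are said of these compounds alone.

Among the compounds with values here, compound 1 `COc1ccc(C(=O)OCC2Oc3ccc([C@H]4Oc5cc(O)cc(O)c5C(=O)[C@@H]4O)cc3OC2c2ccc(O)c(OC)c2)cc1` gives, in a functional assay on liver (Rattus norvegicus, strain Sprague-Dawley) for inhibition, with a stated time of 1 h (on this read-out higher numbers stand for weaker inhibition and lower numbers for stronger inhibition), 21000 nM, the highest of the two numbers so far; compound 2 `COc1cc(C2Oc3cc([C@H]4Oc5cc(O)cc(O)c5C(=O)[C@@H]4O)ccc3OC2COC(=O)c2ccc([N+](=O)[O-])cc2)ccc1O` gives 12600 nM. Within the data shown here, the one measured step, a 1.7-fold lower number from compound 1 to compound 2 (0.22 log units; within the scatter), is the only guide to what the ester part tolerates. Compound 3 `COc1cc(C2Oc3cc([C@H]4Oc5cc(O)cc(O)c5C(=O)[C@@H]4O)ccc3OC2COC(=O)/C=C/c2ccc(Cl)cc2)ccc1O` differs from compound 1 at that same place: 2-(4-chlorophenyl)ethenyl in place of 4-methoxyphenyl on a carbonyl carbon. With a single step at this position, and that one within the scatter, no step beyond the scatter is expected in this assay for compound 3. Compound 3 is therefore estimated at 18000 nM (range 6000 nM to 50000 nM), an expected step of a 1.2-fold lower number from compound 1 to compound 3 (0.07 log units; within the scatter).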

Compound 3, half-maximal inhibitory concentration: 12000 nM
Compound 3: the middle estimate sits 1.5-fold (0.18 log units) above what was measured; low and high end bracket the measured number.
By their numbers in this assay, from the lowest: compounds 3, 2 and 1 (each within the scatter of the next).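

In this assay, the ester position also accepts 2-(4-chlorophenyl)ethenyl, a group with a double bond outside the aromatic ring, with no step beyond the scatter (a 1.8-fold lower number from compound 1 to compound 3 (0.24 log units; within the scatter); a 1.1-fold lower number from compound 2 to compound 3 (0.02 log units; within the scatter)). The three esters on the shared core therefore fall in no readable order. No supporting measurement bears on this result.

On these data alone, whether an ester ending in an amine or a carboxylic acid in place of the aromatic ring would give a step beyond the scatter stays open. As far as these compounds go, how far the ethenyl and the chlorine each count also stays open.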